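Shift from ether to formyl-terminated chain in a butenolide series

A few compounds are considered here, and "the series" means these few. Any claim that something is new, unique, unknown or untested is made for them only; others in the source may bear on it.

Measured so far:
compound 1 `CC(C)(C)C(=O)OCC1(CO)C/C(=C/CCCCCCCCCCCCCCC=O)C(=O)O1`: 5.14 ug/mL
compound 2 `CCCCCOCCCCCCC/C=C1\CC(CO)(COC(=O)C(C)(C)C)OC1=O`: 0.491 ug/mL
compound 3 `COCCCCCCCCCCC/C=C1\CC(CO)(COC(=O)C(C)(C)C)OC1=O`: 0.541 ug/mL

In a functional assay on COLO 205 cells (Homo sapiens) for antiproliferative activity (a higher number here means a weaker inhibitor of growth, a lower number a stronger inhibitor of growth), compound 2 gives the lowest number of the three. Compound 3 sits right beside it: a 1.1-fold higher number from compound 2 to compound 3 (0.04 log units; within the scatter). Compound 1 is the furthest away, its number lying beyond the scatter above that of compound 2.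

Compound 4 `CC(C)(C)C(=O)OCC1(CO)C/C(=C\CCCCCCCCCCCCCCC=O)C(=O)O1` is not yet measured. Relative to compound 2 the change is 7-formylheptyl in place of pentyloxy on a saturated chain carbon, seven bonds along the chain from a double-bonded chain carbon.

Among the compounds with values here, the one measured step, from compound 2 to compound 3, swaps one ether-bearing chain for another and stays within the scatter, so it says little about a chain that now ends in a formyl group. Within the data shown here, the only measured compound carrying a formyl-terminated chain is compound 1, and its number in this assay is far higher than that of compound 2, though no single-point step connects it to compound 4. On that basis the number for compound 4 is expected to rise, a 6.1-fold higher number from compound 2 to compound 4 (0.79 log units; beyond the scatter), and compound 4 is estimated at 3 ug/mL with a range from 0.9 ug/mL to 9 ug/mL.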

Compound 4, concentration for 50% growth inhibition: > 10 ug/mL
Compound 4: only a limit was reported; the forecaster's own chance of this, stated with the estimate: 5%; middle value at least 3.3-fold (0.52 log units) from the limit.
By their numbers in this assay, from the lowest: compounds 2 and 3 (each within the scatter of the next); then compound 1. At a limit, above all of these: compound 4.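

In this assay compound 4 gives > 10 ug/mL, which is a limit and not a number. Putting 7-formylheptyl in place of pentyloxy gives an at least 20-fold higher number from compound 2 to compound 4 (1.30 log units; beyond the scatter), and 3-formylpropyl in place of methoxy gives an at least 18-fold higher number from compound 3 to compound 4 (1.26 log units; beyond the scatter), so at this chain end the change to a formyl terminus is large, whereas the swap between the two ether chains was not. With the same atoms and bonds, the Z and E drawings give an at least 1.9-fold higher number from compound 1 to compound 4 (0.28 log units; that floor lies within the scatter), so this floor does not separate them, and the reading of the pair is tied to: the fact that one of compounds 1 and 4 is drawn with a defined configuration and the other without, at the place where they differ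

As far as these compounds go, the true size of the steps to compound 4 stays open, as does any real effect of the double-bond geometry. Also open, from the compounds shown here alone, is whether a carboxylic acid or a primary amine at the chain end would track the formyl or the ether compounds.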